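The source may hold more compounds than are shown below. What is called first, only, known or untested is meant among the compounds shown, and "the series" means these compounds.

Compound 3, `COC[C@H](NC1CCN(CCCc2c[nH]c3ccc(-n4cnnc4)cc23)CC1)c1ccccc1`, stands lowest of the three numbers in an assay on CHO cells for agonist activity at 5-hydroxytryptamine receptor 1D (Homo sapiens), read by GTPgammaS binding; on this read-out higher numbers stand for an effect only at larger amounts of compound and lower numbers for an effect already at smaller amounts: compound 3 gives 0.9 nM. Compound 1, `c1ccc(CNCC2CCN(CCCc3c[nH]c4ccc(-n5cnnc5)cc34)CC2)cc1`, gives 5.6 nM, and compound 2, `O[C@@H]1Cc2ccccc2[C@H]1NC1CCN(CCCc2c[nH]c3ccc(-n4cnnc4)cc23)CC1`, gives 13 nM. The step of a 6.2-fold lower number from compound 1 to compound 3 (0.79 log units; beyond the scatter) and the step of a 14-fold lower number from compound 2 to compound 3 (1.16 log units; beyond the scatter) both run toward compound 3, while the step of a 2.3-fold higher number from compound 1 to compound 2 (0.37 log units; beyond the scatter) is modest.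

Compound 4, `c1ccc(CNC2CCN(CCCc3c[nH]c4ccc(-n5cnnc5)cc34)CC2)cc1`, differs from compound 3 by hydrogen in place of methoxymethyl on a saturated chain carbon bound to an amine nitrogen and an aromatic carbon. For the measured compounds named here, no measured step isolates this change. The nearest guide is the step of a 6.2-fold lower number from compound 1 to compound 3 (0.79 log units; beyond the scatter), which combines this change with a shortening of the link to the piperidine carbon, so only part of it can be laid to the methoxymethyl group. The step of a 14-fold lower number from compound 2 to compound 3 (1.16 log units; beyond the scatter) shows that the amine substituent can move this assay by a large amount, but it exchanges two different groups.

For compound 4 a somewhat higher number than compound 3 is therefore expected, a step of a 3.9-fold higher number from compound 3 to compound 4 (0.59 log units; beyond the scatter). The estimate for compound 4 is 3.5 nM, with a range from 1.2 nM to 11 nM.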

Compound 4, half-maximal effective concentration: 7.6 nM
Compound 4: middle estimate off by 2.2-fold (0.34 log units), on the low side; the measured number falls inside the stated range.
By their numbers in this assay, from the lowest: compound 3; then compounds 1, 4 and 2 (each within the scatter of the next, the first and the last beyond it).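

With hydrogen in place of methoxymethyl on a saturated chain carbon bound to an amine nitrogen and an aromatic carbon, this assay now gives this change on its own: an 8.4-fold higher number from compound 3 to compound 4 (0.93 log units; beyond the scatter). The other two steps, a 1.4-fold higher number from compound 1 to compound 4 (0.13 log units; within the scatter) and a 1.7-fold lower number from compound 2 to compound 4 (0.23 log units; within the scatter), lie within the scatter, so among these four compounds only compound 3, the one carrying methoxymethyl, stands apart from the rest. No measurement given here accounts for this step.

The compounds shown leave open whether the oxygen of the methoxymethyl group matters, or whether ethyl or hydroxymethyl on the same carbon would give a number like that of compound 3. They also leave open how the opposite configuration at that carbon would read.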